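A few compounds are considered here, and "the series" means these few. Any claim that something is new, unique, unknown or untested is made for them only; others in the source may bear on it.

Four compounds share a core and differ in the group carried on a carbonyl carbon: compound 1 `COc1cc(/C=C/C(=O)c2cccc(NC(=O)c3ccc(Cl)cc3Cl)c2)ccc1O`, compound 2 `COc1cc(/C=C/C(=O)c2cccc(NC(=O)C(C)C)c2)ccc1O`, compound 3 `COC(=O)C(=O)Nc1cccc(C(=O)/C=C/c2ccc(O)c(OC)c2)c1` and the still unmeasured compound 4 `CCOC(=O)C(=O)Nc1cccc(C(=O)/C=C/c2ccc(O)c(OC)c2)c1`. In a functional assay on U-87MG ATCC cells (Homo sapiens) for inhibition (a lower number here means a stronger inhibitor, a higher number a weaker inhibitor), compound 3 gives 12.2 ug/mL. Compound 2 gives 8.31 ug/mL, and the gap between these two is small, with a 1.5-fold higher number from compound 2 to compound 3 (0.17 log units; within the scatter). Compound 1 gives > 50 ug/mL, which is a limit of the assay and not a number. Two steps lead away from that limit, an at least 6.0-fold lower number from compound 1 to compound 2 (0.77 log units; beyond the scatter) and an at least 4.0-fold lower number from compound 1 to compound 3 (0.61 log units; beyond the scatter).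

Compound 4 differs from compound 3 by methyl in place of hydrogen on a saturated chain carbon bound to an oxygen next to a carbonyl group, so methoxycarbonyl becomes ethoxycarbonyl. For the measured compounds named here, no measured step tests this exact change. The closest comparison is the exchange of the whole group in compound 2 for that in compound 3, which stayed small at a 1.5-fold higher number from compound 2 to compound 3 (0.17 log units; within the scatter). The two larger steps both start from compound 1 and replace a whole group, so they say little about a change this limited. In this assay no shift beyond the scatter is therefore expected, and the estimated step is a 1.0-fold lower number from compound 3 to compound 4 (0.01 log units; within the scatter). The estimated value for compound 4 is 12 ug/mL, with an expected range from 6 ug/mL to 25 ug/mL.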

Compound 4, half-maximal inhibitory concentration: > 50 ug/mL
Compound 4: only a limit was reported; the forecaster's own chance of this, stated with the estimate: 5%; at least 4.1-fold (0.61 log units) between middle value and limit.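

In this assay, a single added methyl that turns methoxycarbonyl into ethoxycarbonyl gives an at least 4.0-fold higher number from compound 3 to compound 4 (0.61 log units; beyond the scatter), so a change limited to the saturated chain carbon bound to an oxygen next to a carbonyl group is not a silent one here. For the compounds shown here, the earlier compounds did not show this, since their only step within the scatter was an exchange of isopropyl for methoxycarbonyl, whereas the exchange of isopropyl for ethoxycarbonyl gives an at least 6.0-fold higher number from compound 2 to compound 4 (0.77 log units; beyond the scatter). Compound 4 rests on a limit of the assay and not on a number, as compound 1 does, so both steps give only a minimum size and the step between these two compounds cannot be read: the limit of > 50 ug/mL in this assay, at which 2 of the 4 values shown sit.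

On these data alone, it stays open whether a carboxylic acid or a longer chain such as propoxycarbonyl in this place would stay close to compound 3 or also reach the limit, and so whether the ethyl group marks a sharp edge or a single exception. The whole reading rests on one pair in one assay, and the data do not tell what lies behind the step.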